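The source may hold more compounds than are shown below. What is called first, only, known or untested is meant among the compounds shown, and "the series" means these compounds.

Measured so far in an assay on HEK293 cells for antagonist activity at P2X purinoceptor 7 (Homo sapiens), read by fluorescence, with a stated time of 2 h; on this read-out lower numbers stand for stronger inhibition and higher numbers for weaker inhibition:

Compound 1 `CS(=O)(=O)c1ccc(C(=O)N2CCN(c3cc(=O)[nH]c(=O)n3Cc3ccc(OS(=O)(=O)c4cccc5cnccc45)cc3)CC2)cc1` gives 44 nM.
Compound 2 `O=C(c1ccc([N+](=O)[O-])cc1)N1CCN(c2cc(=O)[nH]c(=O)n2Cc2ccc(OS(=O)(=O)c3cccc4cnccc34)cc2)CC1` gives 27 nM.

For the measured compounds named here, compound 2 stands at 27 nM in this assay, and its only measured neighbour is compound 1; the step of a 1.6-fold lower number from compound 1 to compound 2 (0.21 log units; within the scatter) does not rise above the scatter, so the two numbers cannot be told apart with confidence.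

Compound 3 `CN(C)c1ccc(C(=O)N2CCN(c3cc(=O)[nH]c(=O)n3Cc3ccc(OS(=O)(=O)c4cccc5cnccc45)cc3)CC2)cc1` has not yet been measured. It differs from compound 2 by dimethylamino in place of nitro on an aromatic carbon, on an aromatic carbon of a six-membered aromatic ring of carbon only, para to a large group: 4-nitrophenyl becomes 4-(dimethylamino)phenyl on the carbonyl.

Going by the values given here, the one measured step that bears on this position is a 1.6-fold lower number from compound 1 to compound 2 (0.21 log units; within the scatter), where methylsulfonyl gave way to nitro on the same carbon without a change beyond the scatter. Among the compounds with values here, that is the only guide, and it points to a further swap at this carbon leaving the number much where it is. Compound 3 is therefore expected to give about 40 nM, with a range of 15 nM to 120 nM. This expectation amounts to a 1.5-fold higher number from compound 2 to compound 3 (0.17 log units; within the scatter), a step not expected to exceed the scatter.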

Compound 3, half-maximal inhibitory concentration: 1.53 nM
Estimate against measurement, compound 3: 26-fold (1.42 log units) above; the measured number lies below the stated range.
By their numbers in this assay, from the lowest: compound 3; then compounds 2 and 1 (each within the scatter of the next).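

In this assay, this carbon of the 4-substituted phenyl on the carbonyl proves far from indifferent: the swap between methylsulfonyl and nitro had stayed within the scatter, but dimethylamino brings an 18-fold lower number from compound 2 to compound 3 (1.25 log units; beyond the scatter) and a 29-fold lower number from compound 1 to compound 3 (1.46 log units; beyond the scatter). Both large steps point the same way, so dimethylamino stands apart from the two earlier groups, and the count of heavy atoms does not separate it from nitro, as each group has 3 heavy atoms. No measurement shown here explains why this change has so large an effect.

The compounds shown leave open whether the gain is particular to dimethylamino or would also appear with an amino, methylamino, diethylamino or methoxy group on the same carbon. They also leave open whether dimethylamino would give a step of similar size on a different core, as all three compounds share the core of compound 1 and differ only in this one group.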